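Replacing the Hydroxyphenyl of Compound 2 with a Chlorophenyl

The source may hold more compounds than are shown below. What is called first, only, known or untested is meant among the compounds shown, and "the series" means these compounds.

Compound 2 `CC1=CC[C@@H]([C@@](C)(O)CCCC(C)(C)NC(=S)N/N=C\c2ccc(O)cc2)CC1` carries a 4-hydroxyphenyl on the carbon that is double-bonded to nitrogen. In a functional assay on MCF7 cells (Homo sapiens) for cytotoxicity, read by sulforhodamine B assay (on this read-out higher numbers stand for weaker inhibition of growth and lower numbers for stronger inhibition of growth), compound 2 gives 21200 nM, the lowest of the two plain numbers shown. Compound 1 `COc1ccc(/C=N\NC(=S)NC(C)(C)CCC[C@](C)(O)[C@@H]2CC=C(C)CC2)cc1`, which differs only by a methyl on that oxygen, gives 94900 nM in this assay, so the step of a 4.5-fold lower number from compound 1 to compound 2 (0.65 log units; beyond the scatter) shows that uncapping the oxygen strengthened growth inhibition. Compound 3 `CC1=CC[C@@H]([C@@](C)(O)CCCC(C)(C)NC(=S)N/N=C\c2ccc([N+](=O)[O-])cc2)CC1` carries a nitro group in place of the hydroxy. In this assay compound 3 reaches only a limit, > 100000 nM. The step of an at least 4.7-fold higher number from compound 2 to compound 3 (0.67 log units; beyond the scatter) therefore points toward weaker inhibition.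

Compound 4 `CC1=CC[C@@H]([C@@](C)(O)CCCC(C)(C)NC(=S)N/N=C\c2ccccc2Cl)CC1` makes the change (2-chlorophenyl in place of 4-hydroxyphenyl on a carbon with a double bond to nitrogen). The two measured steps bear on it in the same way: the reverse of a 4.5-fold lower number from compound 1 to compound 2 (0.65 log units; beyond the scatter) and the step of an at least 4.7-fold higher number from compound 2 to compound 3 (0.67 log units; beyond the scatter) both describe losing the free hydroxy and both gave weaker inhibition of growth, though neither involves a chlorine, and compound 3 reveals only a limit. For compound 4 a modest rise in the number is therefore expected, a 3.3-fold higher number from compound 2 to compound 4 (0.52 log units; beyond the scatter) in this assay. Compound 4 is estimated at 70000 nM, with a range from 25000 nM to 150000 nM.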

Compound 4, concentration for total growth inhibition: > 100000 nM
Compound 4: no number, only a limit; the forecaster's own chance of this, stated with the estimate: 25%; middle value at least 1.4-fold (0.15 log units) from the limit.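

At this position, on a carbon with a double bond to nitrogen, 2-chlorophenyl gives an at least 4.7-fold higher number from compound 2 to compound 4 (0.67 log units; beyond the scatter) in this assay, so the loss of growth inhibition seen with the nitro group of compound 3 also appears with a chlorine-bearing ring that has no hydrogen-bond donor or acceptor. On these data alone, compound 4 reaches only a limit, so the true size of this step stays unknown, and the read-out stops at the same point for compound 3: the limit of > 100000 nM in this assay, at which 2 of the 4 values shown sit. The step of an at least 1.0-fold higher number from compound 1 to compound 4 (0.02 log units; that floor lies within the scatter) does not separate these two compounds, and the step between compound 3 and compound 4 cannot be read, since both are limits.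

As far as these compounds go, compound 4 differs from compound 2 both in the group on the ring and in where the group sits, so it stays open whether removing the hydroxy, bringing in the chlorine or moving the substituent accounts for the loss. The compounds shown also say nothing about how a 4-chlorophenyl, which would keep the place of the hydroxy, or a 4-aminophenyl, which would put an amine there, would behave in this assay.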